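Trimming the alkyl chain on the anilide ring

The source may report more compounds than this note shows. Statements on the series, on what has been measured and on what is new or still open speak of the compounds shown alone.

Measured so far in a functional assay on HT-29 cells (Homo sapiens) for antiproliferative activity, read by sulforhodamine B assay, with a stated time of 48 h; on this read-out lower numbers stand for stronger inhibition and higher numbers for weaker inhibition:
compound 1 `CCCCCc1ccc(NS(=O)(=O)c2ccc(N3CCNC3=O)cc2)cc1` gives 990 nM
compound 2 `O=C1NCCN1c1ccc(S(=O)(=O)Nc2ccc(F)c(F)c2)cc1` gives 350 nM
compound 3 `CC(C)(C)c1cc(NS(=O)(=O)c2ccc(N3CCNC3=O)cc2)cc(C(C)(C)C)c1` gives > 1000 nM, a limit of this assay and not a number

Of the two numbers obtained, compound 1 stands highest; the nearest is compound 2, whose number is lower by a gap that lies beyond the usual scatter. Compound 3 reaches only the limit of this assay, as recorded in the limit of > 1000 nM in this assay, at which 1 of the 3 values shown sits. Among the compounds with values here, the shared core of the series is carried by all three; they differ only in the substituents on the anilide ring, and no pair among the measured compounds differs in a single place, so no measured step is available.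

Compound 4 `CCCCc1ccc(NS(=O)(=O)c2ccc(N3CCNC3=O)cc2)cc1` has not yet been measured in this assay. It differs from compound 1 in one place: hydrogen in place of methyl on a saturated chain carbon, four bonds along the chain from an aromatic carbon. The change is confined to a saturated chain carbon, four bonds along the chain from an aromatic carbon, and touches no ring, no donor and no acceptor. Within the data shown here, with no measured step of this kind to draw on, the expected step is a 1.1-fold lower number from compound 1 to compound 4 (0.04 log units; within the scatter), that is, none beyond the scatter, in either direction. Compound 4 is therefore estimated at 900 nM in this assay, with a range from 400 nM to 2000 nM.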

Compound 4, half-maximal inhibitory concentration: 610 nM
Compound 4: middle estimate off by 1.5-fold (0.17 log units), on the high side, and the stated range covers the measured number.
By their numbers in this assay, from the lowest: compounds 2, 4 and 1 (each within the scatter of the next, the first and the last beyond it). At a limit, above all of these: compound 3.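

Within the data shown here, the first measured single-place step concerns the end of the chain on the anilide ring: in this assay, hydrogen in place of methyl on a saturated chain carbon, four bonds along the chain from an aromatic carbon, gives a 1.6-fold lower number from compound 1 to compound 4 (0.21 log units; within the scatter). A single step of this size means that, at this position, removing this one carbon does not separate compound 4 from compound 1 in this read-out, so neither a gain nor a loss can be claimed for the trim, and the outermost carbon of the chain is not shown to matter here. Nothing on hand speaks to the cause of this small step, and no measured property of either compound bears on it.

On these data alone, whether trimming further, to a propyl or an ethyl chain, or extending to a longer chain such as hexyl, would move the number beyond the scatter remains open, and a single step cannot show a trend along the chain. Also open, as far as these compounds go, is what a hydroxyl group or an amine at the chain end would do at this same position.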